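A Methyl Group on the Phenyl Ring of Compound 2

The source may report more compounds than this note shows. Statements on the series, on what has been measured and on what is new or still open speak of the compounds shown alone.

Compound 2 `CC(C)(C)n1ncc(OCc2nnc(-c3ccccc3)s2)c(Cl)c1=O` gives 200 ug/mL in a functional assay on the whole organism for inhibition, with Mythimna separata as the target, with a stated time of 5 days (on this read-out higher numbers stand for an effect only at larger amounts of compound and lower numbers for an effect already at smaller amounts), the highest number of the two compounds measured. Compound 1 `CC(C)(C)n1ncc(OCc2nnc(-c3ccc(Cl)cc3Cl)s2)c(Cl)c1=O` gives 62.2 ug/mL in this assay. Among the measured compounds shown here, the one known step is a 3.2-fold higher number from compound 1 to compound 2 (0.51 log units; beyond the scatter). Compound 3 `Cc1cccc(-c2nnc(COc3cnn(C(C)(C)C)c(=O)c3Cl)s2)c1` differs from compound 2 by methyl in place of hydrogen on an aromatic carbon. Because compound 1 with its substituted phenyl gives 62.2 ug/mL, a substituent on that ring appears to lower the number, though a single methyl is a smaller change than two chlorines. Compound 3 is therefore expected to give 130 ug/mL, between 60 ug/mL and 300 ug/mL, an expected 1.5-fold lower number from compound 2 to compound 3 (0.19 log units; within the scatter).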

Compound 3, half-maximal effective concentration: > 300 ug/mL
Compound 3 was reported as a limit; the forecaster's own chance of this, stated with the estimate: 10%; at least 2.3-fold (0.36 log units) between middle value and limit.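

In this assay, compound 3 is reported as a limit, not a number: > 300 ug/mL. Adding the methyl gives an at least 1.5-fold higher number from compound 2 to compound 3 (0.17 log units; that floor lies within the scatter), so the 3-methylphenyl group shows no gain over plain phenyl, and this floor cannot separate the two. The 2,4-dichlorophenyl group keeps its lead, with an at least 4.8-fold higher number from compound 1 to compound 3 (0.68 log units; beyond the scatter), so a substituent on this ring does not by itself lower the number. Still open, from the compounds shown here alone, is whether a methoxy group or an amine in the same place would lower it, and which chlorine of compound 1 matters.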